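From Pyrazin-2-yl to Pyrimidin-4-yl on a Shared Core

The compounds below may be only part of what the source reports. "The series", "measured", "known", "first", "only" and "open" are said of these compounds alone.

In a functional assay on Huh-7 cells (Homo sapiens) for cytotoxicity, read by MTT assay, with a stated time of 72 h (a higher number here means that more compound is tolerated, a lower number that less compound is tolerated), compound 1 (`CCOC(=O)CCc1sc(Nc2ncccn2)nc1-c1ccccn1`) gives 2050 nM while compound 2 (`CCOC(=O)c1sc(Nc2ncccn2)nc1-c1cnccn1`) gives 590 nM and so holds the lower of the two numbers, which makes it the less tolerated. Compound 3 (`CCOC(=O)c1sc(Nc2ncccn2)nc1-c1ccncn1`) carries pyrimidin-4-yl in place of pyrazin-2-yl on an aromatic carbon, with the same atoms joined differently. For the measured compounds named here, no measured pair shows such a swap, so only a small change is expected in this assay with no firm direction, and the estimated 1.2-fold higher number from compound 2 to compound 3 (0.07 log units; within the scatter) stays within the usual scatter. For compound 3 the expected value is 700 nM with an estimated range from 250 nM to 2000 nM in repeat measurements.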

Compound 3, half-maximal cytotoxic concentration: 1600 nM
Estimate against measurement, compound 3: 2.3-fold (0.36 log units) below, and the stated range covers the measured number.
By their numbers in this assay, from the lowest: compound 2; then compounds 3 and 1 (each within the scatter of the next).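

In this assay, pyrimidin-4-yl in place of pyrazin-2-yl on the aromatic carbon next to the ring nitrogen gives a 2.7-fold higher number from compound 2 to compound 3 (0.43 log units; beyond the scatter), a modest step. This first single-place comparison shows that this position responds to how the atoms of the ring are joined, even with the counts of heavy atoms, donors and acceptors unchanged. Nothing measured here accounts for the step. Still open, on these data alone, is whether a plain phenyl at this position would move the number further, and whether the same swap holds with a carboxylic acid in place of the ethoxycarbonyl group.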